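The source may report more compounds than this note shows. Statements on the series, on what has been measured and on what is new or still open speak of the compounds shown alone.

Measured so far in a functional assay on the whole organism with Rattus norvegicus as the target; a lower number here means that less compound is needed, a higher number that more compound is needed for the effect

- compound 1 `O=C(/C=C1\CCc2ccc(F)cc21)NC1CCCC1` gives 14 mg/kg
- compound 2 `NC(=O)/C=C1\CCc2cc(F)c(F)cc21` gives 13 mg/kg
- compound 3 `O=C(/C=C1\CCc2ccc(F)cc21)NCc1ccccc1` gives 16 mg/kg

Compound 3 at 16 mg/kg sits level with compound 1 and compound 2, since all three values lie within the usual scatter of one another. The next compound is compound 4 `O=C(/C=C1\CCc2ccc(F)cc21)Nc1ccccc1` and the change leading to it is phenyl in place of benzyl on an amide-type nitrogen with phenyl in place of benzyl on an amide-type nitrogen.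

Within the data shown here, one measured step bears on this change. It is a 1.1-fold higher number from compound 1 to compound 3 (0.06 log units; within the scatter) with benzyl in place of cyclopentyl on that same kind of nitrogen, and it stays within the scatter. Among the measured compounds shown here, compound 2 differs from the others in more than one place and offers no single step. For the measured compounds named here, no measured compound carries phenyl on this nitrogen, and one step is thin evidence, so the expectation remains uncertain.

In this assay the expected step is a 1.1-fold higher number from compound 3 to compound 4 (0.03 log units; within the scatter) and so none beyond the scatter. Compound 4 is expected at 17 mg/kg within an estimated range of 8 mg/kg to 36 mg/kg.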

Compound 4, dose for half-maximal effect: 8 mg/kg
Estimate against measurement, compound 4: 2.1-fold (0.33 log units) above; the range from low to high includes it.
By their numbers in this assay, from the lowest: compounds 4, 2, 1 and 3 (each within the scatter of the next).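

In this assay, phenyl in place of benzyl on the amide-type nitrogen gives a 2.0-fold lower number from compound 3 to compound 4 (0.30 log units; within the scatter), and phenyl in place of cyclopentyl gives a 1.8-fold lower number from compound 1 to compound 4 (0.24 log units; within the scatter). With phenyl added, this nitrogen has now carried three different carbon-only groups, and neither new step stands clear of the scatter, so the result gives no firm sign that the choice among these groups matters in this whole-animal test. Nothing available explains these numbers.

On these data alone, whether a longer chain, such as phenylethyl, would give a real difference on this nitrogen remains open. The same is true of a group carrying an amine or a carboxylic acid, which would show whether this position tolerates something other than plain carbon groups.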